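Thiocarbamate-linked benzamides: replacing the piperidine on the thiocarbonyl

A few compounds are considered here, and "the series" means these few. Any claim that something is new, unique, unknown or untested is made for them only; others in the source may bear on it.

Measured so far:
compound 1 `CC1CCCCN1C(=S)SCc1ccc(C(=O)Nc2ccccc2N)cc1`: 85.2%
compound 2 `Nc1ccccc1NC(=O)c1ccc(CSC(=S)N2CCN(C(c3ccccc3)c3ccccc3)CC2)cc1`: 8.4%
compound 3 `Nc1ccccc1NC(=O)c1ccc(CSC(=S)N2CCN(c3ncccn3)CC2)cc1`: 67.9%

In a functional assay on A-375 cells (Homo sapiens) for antiproliferative activity, read by CCK-8 assay, with a stated time of 72 h, tested at 8 uM (on this read-out higher numbers stand for a stronger effect at the one concentration tested and lower numbers for a weaker effect), compound 1 gives the highest number of the three. Compound 3 sits below it by a gap beyond the scatter, and compound 2 lies far lower still, so the group on the thiocarbonyl carbon clearly moves the read-out. Compound 4 `CN(C(=S)SCc1ccc(C(=O)Nc2ccccc2N)cc1)c1cccnc1` has not been measured. It differs from compound 1 as follows: methyl(pyridin-3-yl)amino in place of 2-methylpiperidin-1-yl on a thiocarbonyl carbon. Within the data shown here, no pair of measured compounds shares this exact change, so the expected step rests on the spread seen above. A modest loss is expected, a number 20.2 percentage points lower from compound 1 to compound 4 (beyond the scatter), since the smaller cyclic amine of compound 1 gave 85.2% while the other substituted amines fell lower. For compound 4 the estimate is 65%, ranging from 35% to 88%.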

Compound 4, a percentage reported as inhibition, at one concentration (the size of the read-out at that concentration, not a potency): 87.7%
Compound 4: middle estimate off by 22.7 percentage points, on the low side, and the stated range covers the measured number.
By their numbers in this assay, from the lowest: compound 2; then compound 3; then compounds 1 and 4 (each within the scatter of the next).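

In this assay, methyl(pyridin-3-yl)amino in place of 2-methylpiperidin-1-yl on a thiocarbonyl carbon gives a number 2.5 percentage points higher from compound 1 to compound 4 (within the scatter) as the first step readable at this position. A six-membered non-aromatic ring on the amine is therefore not needed to keep this read-out, since a six-membered aromatic ring with one hetero atom serves there as well. Nothing available explains this outcome.

Still open, on these data alone, is whether the read-out holds with phenyl in place of the pyridin-3-yl ring, or with ethyl in place of the methyl. A morpholine on the thiocarbonyl carbon would further test how much variation this position accepts.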